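This account rests on a few compounds, and the source may have more. Where it says the series, first, only, none or still open, it means among the compounds named here.

Measured so far in a functional assay on HepG2 cells (Homo sapiens) for cytotoxicity, read by MTT assay, with a stated time of 48 h; a lower number here means a stronger inhibitor, a higher number a weaker inhibitor:
- compound 1 `O=C(CSc1nnc(-c2ccncc2)o1)N/N=C/c1ccccc1`, 17300 nM
- compound 2 `O=C(CSc1nnc(-c2ccncc2)o1)N/N=C/c1ccc(Br)cc1`, 18600 nM

Among the compounds with values here, on these two numbers compound 2 stands highest, but the only step, a 1.1-fold higher number from compound 1 to compound 2 (0.03 log units; within the scatter), lies within the scatter, so the two compounds are not separated. Compound 3 `O=C(CSc1nnc(-c2ccncc2)o1)N/N=C/c1ccc([N+](=O)[O-])cc1` is not yet measured; it differs from compound 2 by nitro in place of bromo on an aromatic carbon. Within the data shown here, no measured step touches a nitro group; the one step that bears on a change at this aromatic carbon is a 1.1-fold higher number from compound 1 to compound 2 (0.03 log units; within the scatter), which was within the scatter. Compound 3 is therefore expected to show no step beyond the scatter, estimated as a 1.0-fold lower number from compound 2 to compound 3 (0.01 log units; within the scatter). Compound 3 is estimated at 18000 nM, with a range from 7000 nM to 45000 nM.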

Compound 3, half-maximal inhibitory concentration: 17900 nM
Beside the measured number, compound 3's estimate is 1.0-fold (0.00 log units) above it; low and high end bracket the measured number.
By their numbers in this assay, from the lowest: compounds 1, 3 and 2 (each within the scatter of the next).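

In this assay, 4-bromophenyl to 4-nitrophenyl gives a 1.0-fold lower number from compound 2 to compound 3 (0.02 log units; within the scatter), and nitro in place of hydrogen on the same aromatic carbon gives a 1.0-fold higher number from compound 1 to compound 3 (0.01 log units; within the scatter). Both steps lie within the scatter, so hydrogen, bromo and nitro at this carbon are not separated, even though nitro brings three heavy atoms and two hydrogen-bond acceptors where bromo has one heavy atom and none. No evidence on these compounds accounts for this result.

From the compounds shown here alone, whether an amine, a carboxylic acid or a longer chain at this carbon would give a step beyond the scatter remains open. So does the effect of any change elsewhere on the shared core.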